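The source may hold more compounds than are shown below. What is called first, only, known or untested is meant among the compounds shown, and "the series" means these compounds.

Measured compounds:

- compound 1, `O=C(CN1C(=O)/C(=C/c2ccc(-c3ccc(Cl)cc3)o2)SC1=S)NCc1ccc(C(F)(F)F)cc1`: 170000 nM
- compound 2, `N#Cc1ccc(NC(=O)CN2C(=O)/C(=C/c3ccc(-c4ccc(Cl)cc4)o3)SC2=S)cc1`: 90000 nM

Both were read in a functional assay on REH cells (Homo sapiens) for cytotoxicity, read by MTT assay, with a stated time of 72 h; a higher number here means a weaker inhibitor, a lower number a stronger inhibitor. Compound 2 gives 90000 nM, the lowest of the two numbers, but its nearest neighbour compound 1 gives 170000 nM, and the step of a 1.9-fold lower number from compound 1 to compound 2 (0.28 log units; within the scatter) lies within the scatter, so no order between the two can be claimed.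

Compound 3, `CCCNC(=O)CN1C(=O)/C(=C/c2ccc(-c3ccc(Cl)cc3)o2)SC1=S`, has not yet been measured. It differs from compound 2 at a single place: propyl in place of 4-cyanophenyl on an amide-type nitrogen. Going by the values given here, the one measured step that bears on this position, a 1.9-fold lower number from compound 1 to compound 2 (0.28 log units; within the scatter), exchanged one substituent on the amide-type nitrogen for another and left the number within the scatter. No measured compound carries a propyl or any chain at this nitrogen, so the effect of this particular exchange is not shown by the data.

Given that one exchange at this nitrogen produced no step beyond the scatter, compound 3 is expected to give about 120000 nM, with a range from 40000 nM to 350000 nM. The estimated step of a 1.3-fold higher number from compound 2 to compound 3 (0.12 log units; within the scatter) is therefore expected to stay within the scatter.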

Compound 3, half-maximal inhibitory concentration: 55000 nM
Compound 3: middle estimate off by 2.2-fold (0.34 log units), on the high side; the range from low to high includes it.
By their numbers in this assay, from the lowest: compounds 3, 2 and 1 (each within the scatter of the next, the first and the last beyond it).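

In this assay, replacing the aromatic 4-cyanophenyl with propyl gives a 1.6-fold lower number from compound 2 to compound 3 (0.21 log units; within the scatter), so at this amide-type nitrogen a small chain without a ring gives a number that cannot be told apart from that of compound 2, and an aromatic ring on this substituent is not needed to stay in this range. The comparison with the benzyl-type amide gives a 3.1-fold lower number from compound 1 to compound 3 (0.49 log units; beyond the scatter), the first step among these compounds to lie beyond the scatter, showing that the substituent on this nitrogen can shift the number, if only modestly, although compound 2 cannot be separated from either of the other two. No measurement shown here accounts for this difference between compound 1 and compound 3.

As far as these compounds go, it remains open whether a longer chain such as hexyl, or a chain ending in an amine or a carboxylic acid, would extend this shift or reverse it at the same nitrogen. From the compounds shown here alone, since all three compounds share one core, it is also open whether the small step seen with propyl would hold on any other core.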